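A pyridin-4-yl swap at the assay limit

This account rests on a few compounds, and the source may have more. Where it says the series, first, only, none or still open, it means among the compounds named here.

Compound 1 (`O=C(Nc1cccc(F)c1)c1cc(=O)[nH]c2cc(F)ccc12`): > 20000 nM (limit)
Compound 2 (`Cc1ccc(-c2ccc3c(C(=O)Nc4cccc(F)c4)cc(=O)[nH]c3c2)cc1`): > 20000 nM (limit)

In a functional assay on KYSE-70 cells for antiproliferative activity against KYSE-70 cell line (Homo sapiens), read by MTT assay, with a stated time of 72 h (a higher number here means a weaker inhibitor, a lower number a stronger inhibitor), compound 2 gives > 20000 nM as a limit and not a number. Compound 1 likewise gives > 20000 nM as a limit. The two compounds thus stand together (the limit of > 20000 nM in this assay, at which 2 of the 2 values shown sit) and neither has an exact potency.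

For the measured compounds named here, the one measured step is a step that the two limits leave unreadable from compound 1 to compound 2 and it put 4-methylphenyl in place of fluoro on an aromatic carbon. Its two limits give no size to carry forward.

Compound 3 (`O=C(Nc1cccc(F)c1)c1cc(=O)[nH]c2cc(-c3ccncc3)ccc12`) has not yet been measured. It carries pyridin-4-yl in place of 4-methylphenyl on an aromatic carbon and so differs from compound 2 in that one group.

Going by the values given here, with a step that the two limits leave unreadable from compound 1 to compound 2 as the only guide, no step beyond the scatter is expected in this assay in either direction. The estimate means a number no higher from compound 2 to compound 3 (the limit leaves the size open) as an expected result. For compound 3 the estimate is 20000 nM with an expected range from 8000 nM to 30000 nM and the assay may well report only a limit again.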

Compound 3, half-maximal inhibitory concentration: > 20000 nM
Compound 3 ended at the assay's limit; the forecaster's own chance of this, stated with the estimate: 80%; the middle value sits exactly at the limit.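

Compound 3 also ends at a limit in this assay, so no step can be read among compound 1, compound 2 and compound 3, and none of them has an exact potency: the limit of > 20000 nM in this assay, at which 3 of the 3 values shown sit. The compounds shown leave open whether fluoro, 4-methylphenyl or pyridin-4-yl at this place makes any difference to potency.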